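Amine substituent variation on the shared core: cytotoxicity notes

The compounds below may be only part of what the source reports. "The series", "measured", "known", "first", "only" and "open" are said of these compounds alone.

Measured compounds in a functional assay on HEL cells (Homo sapiens) for cytotoxicity, read by microscopy; on this read-out higher numbers stand for lower toxicity in this test and lower numbers for higher toxicity in this test:
- compound 1 `Cc1cn([C@@H]2O[C@H](CO[Si](C)(C)C(C)(C)C)[C@@]3(OS(=O)(=O)C=C3NC(N)=O)[C@H]2O[Si](C)(C)C(C)(C)C)c(=O)n(C)c1=O`, giving 16000 nM
- compound 2 `Cc1cn([C@@H]2O[C@H](CO[Si](C)(C)C(C)(C)C)[C@@]3(OS(=O)(=O)C=C3NCC(=O)OCc3ccccc3)[C@H]2O[Si](C)(C)C(C)(C)C)c(=O)n(C)c1=O`; for compound 2 the result is only the limit of the test, >= 400000 nM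
- compound 3 `Cc1cn([C@@H]2O[C@H](CO[Si](C)(C)C(C)(C)C)[C@@]3(OS(=O)(=O)C=C3NCC(=O)C(=O)O)[C@H]2O[Si](C)(C)C(C)(C)C)c(=O)n(C)c1=O`, giving 400000 nM

Compound 3 stands at the top of the two numbers available; its nearest neighbour is compound 1, with a 25-fold higher number from compound 1 to compound 3 (1.40 log units; beyond the scatter). Against compound 2 only a number no higher from compound 2 to compound 3 (the limit leaves the size open) can be said, since that value is a limit (the limit of >= 400000 nM in this assay, at which 1 of the 3 values shown sits).

The next compound is compound 4 `Cc1cn([C@@H]2O[C@H](CO[Si](C)(C)C(C)(C)C)[C@@]3(OS(=O)(=O)C=C3NCCC(=O)O)[C@H]2O[Si](C)(C)C(C)(C)C)c(=O)n(C)c1=O`. Its difference from compound 3 is carboxymethyl in place of carboxycarbonyl on a saturated chain carbon bound to an amine nitrogen. For the measured compounds named here, no measured step touches this exact change. The steps that exist show that replacing the carbamoyl of compound 1 moves the number far, an at least 25-fold higher number from compound 1 to compound 2 (1.39 log units; beyond the scatter) and a 25-fold higher number from compound 1 to compound 3 (1.40 log units; beyond the scatter), while the change from benzyloxy to carboxy, a number no higher from compound 2 to compound 3 (the limit leaves the size open), is not readable in size. Both compound 3 and compound 4 carry a carboxy group on the amine-bound chain, so in this assay no step beyond the scatter is expected, a 1.3-fold lower number from compound 3 to compound 4 (0.12 log units; within the scatter).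

Compound 4 is therefore estimated at 300000 nM, with a range from 100000 nM to 800000 nM, and a fair chance that only a limit is reported.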

Compound 4, minimum cytotoxic concentration: 80000 nM
Beside the measured number, compound 4's estimate is 3.8-fold (0.57 log units) above it; the whole stated range lies above it.
By their numbers in this assay, from the lowest: compound 1; then compound 4; then compound 3.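

Having a carboxy group on the amine-bound chain does not by itself settle the number in this assay: carboxymethyl in place of carboxycarbonyl, on a saturated chain carbon bound to an amine nitrogen, gives a step beyond the scatter (a 5.0-fold lower number from compound 3 to compound 4 (0.70 log units; beyond the scatter)). Carboxymethyl in place of benzyloxycarbonyl also reads as a step beyond the scatter (an at least 5.0-fold lower number from compound 2 to compound 4 (0.69 log units; beyond the scatter)), although its starting value is a limit of the assay: the limit of >= 400000 nM in this assay, at which 1 of the 4 values shown sits. Against carbamoyl on the amine nitrogen, 2-carboxyethyl still gives a higher number (a 5.0-fold higher number from compound 1 to compound 4 (0.70 log units; beyond the scatter)), so the rise on leaving carbamoyl remains with this chain but is smaller than with (carboxycarbonyl)methyl.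

The compounds shown do not separate the effect of the carbonyl in the chain from the effect of the acid end, and a methyl ester or a primary amine at the end of the same chain would bear on that. On these data alone, whether the number keeps moving with chain length also stays open, and a longer chain such as 3-carboxypropyl on the same amine nitrogen would address it.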